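A few compounds are considered here, and "the series" means these few. Any claim that something is new, unique, unknown or untested is made for them only; others in the source may bear on it.

The measured compounds:
compound 1, `C=CCCOc1ncc(-c2ccccc2OC)n1C`, gives 22000 nM in a functional assay on A549 cells (Homo sapiens) for inhibition, read by colorimetric assay and MTT assay, with a stated time of 72 h; on this read-out lower numbers stand for stronger inhibition and higher numbers for weaker inhibition;
compound 2, `C=CCCCCOc1ncc(-c2ccccc2OC)n1C`, gives 5000 nM;
compound 3, `C=CCCCCOc1ccccc1-c1cnc(S(=O)(=O)c2ccccc2)n1C`, gives 38000 nM.

Compounds 1 and 2 share one core and differ in a single place: vinyl in place of but-3-en-1-yl on a saturated chain carbon, two bonds along the chain from an oxygen on an aromatic ring. That change made a measured step, a 4.4-fold higher number from compound 2 to compound 1 (0.64 log units; beyond the scatter), so shortening the chain on this core went with a clearly weaker result. Compound 3 carries a different core, and the difference between the two cores is not broken down here; what the values show is that compound 3 stands nearest to compound 1 and furthest from compound 2 in this assay.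

Compound 4, `C=CCCOc1ccccc1-c1cnc(S(=O)(=O)c2ccccc2)n1C`, is not yet measured. It differs from compound 3 in one place: vinyl in place of but-3-en-1-yl on a saturated chain carbon, two bonds along the chain from an oxygen on an aromatic ring. This is the same change that turns compound 2 into compound 1, and the place is described in the same words for both pairs, so the account treats it as the same change on a different core.

The expectation for compound 4 rests on that one earlier step. Because compound 1 stands at 22000 nM against compound 2 at 5000 nM, the shortening is expected to weaken compound 4 in the same direction, and the step is estimated as a 3.4-fold higher number from compound 3 to compound 4 (0.53 log units; beyond the scatter). Going by the values given here, compound 4 is therefore estimated at 130000 nM, with a range from 50000 nM to 350000 nM, noting that only one earlier step supports the size and that a core this weak may end at a limit of the assay.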

Compound 4, half-maximal inhibitory concentration: 73000 nM
Compound 4: middle estimate off by 1.8-fold (0.25 log units), on the high side, within the range that was stated.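

On the core of compound 3, putting vinyl in place of but-3-en-1-yl gave a 1.9-fold higher number from compound 3 to compound 4 (0.28 log units; within the scatter) in this assay, so on this core alone the change does not separate the two compounds. Set beside the earlier step, the result gives no sign that the two cores respond differently, and the gap between the steps is no larger than two such steps can show by chance: the same change on two cores in this assay, a 4.4-fold higher number (0.64 log units; beyond the scatter) from compound 2 to compound 1 and a 1.9-fold higher number (0.28 log units; within the scatter) from compound 3 to compound 4, 2.3-fold (0.36 log units) apart, within the scatter of two such steps. Going by these compounds alone, this means the series is consistent with the change carrying from one core to the other, but it does not show a fixed size for the step, since only two pairs support the comparison and only the pair on the core of compound 1 shows a step beyond the scatter.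

The compounds shown leave open whether the same change would behave alike on a third core, since two cores are too few to say how general it is. They also leave open how a longer chain than hex-5-en-1-yl, or a chain ending in an amine or a carboxylic acid in place of the double bond, would read in this assay on either core.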